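Cytotoxicity of a cyclic amide series on Huh-7 cells

The source may report more compounds than this note shows. Statements on the series, on what has been measured and on what is new or still open speak of the compounds shown alone.

Compound 1 `CC(C)CCN1C(=O)C(C2=NS(=O)(=O)c3cc(NS(C)(=O)=O)ccc3N2)=C(O)C2CCCC21` gives, in an ADME assay on Huh-7 cells (Homo sapiens) for cytotoxicity, with a stated time of 72 h (on this read-out higher numbers stand for lower toxicity in this test and lower numbers for higher toxicity in this test), a limit of > 1000 nM. Compound 2 `CC(C)CCN1C(=O)C(C2=NS(=O)(=O)c3cc(NS(C)(=O)=O)ccc3N2)=C(O)[C@H]2CCC[C@H]21` gives in this assay a limit of > 1000 nM. Compound 3 `CS(=O)(=O)Nc1ccc2c(c1)S(=O)(=O)N=C(C1=C(O)C3CCCCC3N(C3CCCCC3)C1=O)N2` gives in this assay a limit of > 33000 nM.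

Compound 1 therefore stands only at a limit in this assay, as do the two other compounds. The step from compound 1 to compound 2 is a step that the two limits leave unreadable from compound 1 to compound 2; the two structures differ only in that compound 2 is drawn with configurations at two ring carbons (the fact that one of compounds 1 and 2 is drawn with a defined configuration and the other without, at the place where they differ). Among the compounds with values here, no step between compound 1 and compound 3 is given; both values are limits.

Compound 4 `CS(=O)(=O)Nc1ccc2c(c1)S(=O)(=O)N=C(C1=C(O)C3CCCC3N(Cc3ccc(Cl)cc3)C1=O)N2` differs from compound 1 by 4-chlorophenyl in place of isobutyl on a saturated chain carbon bound to an amide-type nitrogen in a ring, that is, isopentyl to 4-chlorobenzyl. No measured step bears on this change, and every measurement shown is a limit of > 1000 nM in this assay, at which 2 of the 3 values shown sit (the limit of > 33000 nM in this assay, at which 1 of the 3 values shown sits). Compound 4 is therefore expected to give a limit again, with an estimated step that the limit leaves unreadable from compound 1 to compound 4 and a value around 20000 nM, in the range 2000 nM to 100000 nM.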

Compound 4, half-maximal cytotoxic concentration: > 10000 nM
Compound 4 gave a limit, no number (the forecaster's own chance of this, stated with the estimate: 85%); the middle value is on the limit's open side.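

Compound 1 and compound 4 both stand only at limits in this assay, and the step between them cannot be read. The compounds shown leave open whether isopentyl to 4-chlorobenzyl changes the half-maximal cytotoxic concentration at all.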